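A Ring Swap on an Amide Nitrogen, Starting From Inactivity

The compounds below may be only part of what the source reports. "The series", "measured", "known", "first", "only" and "open" are said of these compounds alone.

Compound 1 `CCN(C(=O)COc1ccc(C)cc1)C(C)c1cccs1` was examined in an assay on HEK293 cells for agonist activity at transient receptor potential cation channel subfamily M member 8 (Homo sapiens), read by fluorescence and calcium flux, with a stated time of 15 min (on this read-out higher numbers stand for an effect only at larger amounts of compound and lower numbers for an effect already at smaller amounts), and compound 1 came back as "not active" (no number reported), so no single number marks where it stands. Among the measured compounds shown here, a second compound of the same series, compound 2 `Cc1ccc(OCC(=O)N(Cc2cccs2)c2ccccc2)cc1`, gives 23 nM in this assay; the two structures differ in more than one place, so the pair shows only that one member has a number and the other does not. The step to compound 3 `CCN(Cc1cn[nH]c1)C(=O)COc1ccc(C)cc1` changes ((1H-pyrazol-4-yl)methyl in place of 1-(thiophen-2-yl)ethyl on an amide-type nitrogen). For the measured compounds named here, with no number for compound 1 and no measured step joining it to compound 3, he expects no shift in this assay that could be told from the scatter, and compound 3 is expected to behave much as compound 1 did. He estimates compound 3 at 20000 nM, within a range from 3000 nM to 100000 nM, and he expects that a limit rather than a number is the more likely report.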

Compound 3, half-maximal effective concentration: "active" (no number reported)
Compound 3: no number reported, and the estimate cannot be compared.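

In this assay, among the compounds shown here, compound 1 gives "not active" (no number reported) and compound 3 gives "active" (no number reported) so no step between the two can be read. The compounds shown leave open what number compound 3 would carry on this read-out. Nothing shown offers an explanation for this result.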